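The source may hold more compounds than are shown below. What is called first, only, known or untested is meant among the compounds shown, and "the series" means these compounds.

Going by the values given here, in a functional assay on A549 cells (Homo sapiens) for antiproliferative activity, read by MTT assay (a higher number here means a weaker inhibitor, a lower number a stronger inhibitor), only two compounds with the same shared core have been tested so far. Compound 1 `CC(=O)c1ccc(-n2cc(COc3ccc(/C=C/C(=O)c4cc5c(cc4O)OC(C)(C)CC5)cc3)nn2)cc1` gives 66300 nM, which is weak activity. Compound 2 `CC1(C)CCc2c(ccc(C(=O)/C=C/c3ccc(OCc4cn(-c5ccc(Cl)cc5)nn4)cc3)c2O)O1` is recorded as "not active" (no number reported). No single number exists for compound 2, so it cannot be placed exactly on the scale.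

Compound 3 `CC1(C)CCc2c(ccc(C(=O)/C=C/c3ccc(OCc4cn(Cc5ccc([N+](=O)[O-])cc5)nn4)cc3)c2O)O1` changes one group of compound 2: 4-nitrobenzyl in place of 4-chlorophenyl on an aromatic nitrogen. Here, 4-nitrobenzyl stands in place of 4-chlorophenyl on an aromatic nitrogen of the five-membered aromatic ring with 3 nitrogen.

Without a number for compound 2, the size of this step cannot be calculated. The expected direction is a small move, from no reported activity to weak activity at best, and nothing in these data suggests a large gain. Among the compounds with values here, the only measured reference is compound 1 at 66300 nM, so that level is the sensible anchor for an expectation. Compound 3 could also turn out to have no reportable number.

If a number is obtained, the expected value for compound 3 is 60000 nM, with an estimated range from 20000 nM to 150000 nM.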

Compound 3, half-maximal inhibitory concentration: 69900 nM
Estimate against measurement, compound 3: 1.2-fold (0.07 log units) below; measured number inside the range.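

In this assay, going by these compounds alone, compound 3 gives 69900 nM but compound 2 carries no single number, so no step from compound 2 to compound 3 can be read. The compounds shown leave open how much 4-nitrobenzyl in place of 4-chlorophenyl changes activity. No measured evidence bears on this result.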